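A few compounds are considered here, and "the series" means these few. Any claim that something is new, unique, unknown or untested is made for them only; others in the source may bear on it.

Working notes on the series. Compound 1 `Cc1cn(C2CC(N=[N+]=[N-])C(COC(=O)OCCCO)O2)c(=O)[nH]c1=O` gives -0.98 in a physicochemical assay for lipophilicity; a lower number here means a more polar compound, a higher number a more lipophilic compound. Compound 2 `Cc1cn(C2CC(N=[N+]=[N-])C(COC(=O)NCCCO)O2)c(=O)[nH]c1=O`, with (3-hydroxypropyl)amino in place of 3-hydroxypropoxy on a carbonyl carbon, gives -1.24; the step of a number 0.26 log units lower from compound 1 to compound 2 (within the scatter) is small. Compound 3 `Cc1cn(C2CC(N=[N+]=[N-])C(COC(=O)NCCCC(=O)OC(C)(C)C)O2)c(=O)[nH]c1=O` gives 0.88; the step of a number 2.12 log units higher from compound 2 to compound 3 (beyond the scatter) is the one large move so far. Compound 3 stands highest of the three values, compound 1 nearest to it and compound 2 furthest, both separations beyond the scatter.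

Compound 4 `Cc1cn(C2CC(N=[N+]=[N-])C(COC(=O)NCCCN)O2)c(=O)[nH]c1=O` is not yet measured. Its difference from compound 3 is amino in place of tert-butoxycarbonyl on a saturated chain carbon, three bonds along the chain from an amide-type nitrogen. Among the compounds with values here, the only step that bears on this position is a number 2.12 log units higher from compound 2 to compound 3 (beyond the scatter), which brought tert-butoxycarbonyl in at the same place; the change to compound 4 removes that group and puts amino there instead. The step of a number 0.26 log units lower from compound 1 to compound 2 (within the scatter) concerns another position and lies within the scatter, so it gives no guidance here. A large step downward, of roughly the size seen when tert-butoxycarbonyl entered, is therefore expected: a number 2.48 log units lower from compound 3 to compound 4 (beyond the scatter). For compound 4 the estimated value is -1.6, expected to fall between -2.4 and -0.8.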

Compound 4, partition coefficient: -1.19
Estimate against measurement, compound 4: 0.41 log units below; measured number inside the range.
By their numbers in this assay, from the lowest: compounds 2, 4 and 1 (each within the scatter of the next); then compound 3.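

In this assay, the large step seen when tert-butoxycarbonyl entered on a saturated chain carbon, three bonds along the chain from an amide-type nitrogen, now has a counterpart in the opposite direction, with amino as the replacement: a number 2.07 log units lower from compound 3 to compound 4 (beyond the scatter). Amino and hydroxy at this place cannot be told apart, with a number 0.05 log units higher from compound 2 to compound 4 (within the scatter), and the change of the whole side chain from 3-hydroxypropoxy to (3-aminopropyl)amino on the carbonyl carbon also stays inside the noise, with a number 0.21 log units lower from compound 1 to compound 4 (within the scatter), so that among these four compounds only compound 3 stands apart. Nothing measured here accounts for the size of these steps.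

The compounds shown leave open whether the large step needs the whole tert-butoxycarbonyl group or only part of it, a question that a carboxylic acid or a methyl ester at the same place would address. They also leave open whether the match between amino and hydroxy holds for a longer chain or for a dimethylamine in place of the amino group.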